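The source may hold more compounds than are shown below. What is called first, only, known or untested is meant among the compounds shown, and "the series" means these compounds.

Working notes on the series. Of the compounds shown here, three have been measured in an assay for inhibition of acyl-CoA:cholesterol acyltransferase (Oryctolagus cuniculus), using microsomes; a lower number here means a stronger inhibitor, a higher number a weaker inhibitor. Compound 1 `CCCCCCCCCCC(C)(C)C(=O)Nc1c(C)c([N+](=O)[O-])c(C)c2c1OC(C)(C)C2` gives 36 nM. Compound 2 `CCCCCCCCCCC1(C(=O)Nc2cccc3c2OC(C)(C)C3)CCCC1` gives 500 nM. Compound 3 `Cc1cc(C)c(NC(=O)C(C)(C)CCCc2ccc(CC(C)C)cc2)c2c1CC(C)(C)O2` gives 40 nM. Among these numbers compound 3 stands second highest of the three; its nearest neighbour is compound 1, whose value lies within the usual scatter of it, so the two cannot be ordered; compound 2 lies furthest away, with a value beyond the scatter that marks compound 2 as the weaker inhibitor of that pair. Among the measured compounds shown here, no two of the measured compounds differ in a single place, so no counted step exists among them.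

Compound 4 `Cc1cc(C)c(NC(=O)C(C)(C)CCCCCCOc2ccc(Cl)cc2)c2c1CC(C)(C)O2` has not been measured. It keeps the core of compound 3 and differs from it by 3-(4-chlorophenoxy)propyl in place of 4-isobutylphenyl on a saturated chain carbon, four bonds along the chain from a carbonyl carbon. For the measured compounds named here, the measured compounds offer no step that isolates this kind of exchange; what they do show is that compound 1, with a long saturated chain at the amide, and compound 3, with an aryl-terminated chain there, sit within the scatter of each other. The expectation for compound 4 in this assay is therefore no step beyond the scatter in either direction, a 1.3-fold lower number from compound 3 to compound 4 (0.12 log units; within the scatter). Compound 4 is estimated at 30 nM, within 10 nM to 90 nM.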

Compound 4, half-maximal inhibitory concentration: 76 nM
For compound 4 the middle estimate is 2.5-fold (0.40 log units) below the measured one; low and high end bracket the measured number.
By their numbers in this assay, from the lowest: compounds 1, 3 and 4 (each within the scatter of the next, the first and the last beyond it); then compound 2.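

Among the compounds shown here, at the saturated chain carbon, four bonds along the chain from a carbonyl carbon, putting 3-(4-chlorophenoxy)propyl in place of 4-isobutylphenyl gives a 1.9-fold higher number from compound 3 to compound 4 (0.28 log units; within the scatter) in this assay, and this is the only counted step so far. For the compounds shown here, it shows that this position takes an exchange of one aryl-bearing group for another, one that brings in an oxygen, a chlorine and one hydrogen-bond acceptor, without a step beyond the scatter; the earlier compounds differed in several places at once and could not show this. No measurement at hand offers an explanation for this step.

As far as these compounds go, the ether oxygen and the chlorine enter together, so this single step does not separate them, and it remains open whether a plain phenoxy end, without chlorine, would stay within the scatter of compound 3. Also open, from the compounds shown here alone, is whether a carboxylic acid or an amine at the end of the chain, or a much shorter chain, would be tolerated at this position on the core of compound 3.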